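This account rests on a few compounds, and the source may have more. Where it says the series, first, only, none or still open, it means among the compounds named here.

Series notes, three measured ureas sharing the cyanoaziridine carbonyl core. In a functional assay on RPMI-8226 cells (Homo sapiens) for inhibition (on this read-out lower numbers stand for stronger inhibition and higher numbers for weaker inhibition), compound 1 `CCOC(=O)c1ccc(NC(=O)N2CC2C#N)cc1` gives 3000 nM, the lowest number of the three. Compound 2 `N#CC1CN1C(=O)NC1CCCCC1` gives 36000 nM in this assay, and compound 3 `CC(C)(C)NC(=O)N1CC1C#N` gives 120000 nM. Both gaps from compound 1 are reported as beyond the scatter, so compound 1 is the most active of the set, and the two compounds that carry a saturated substituent on the urea nitrogen in place of the aromatic ring sit well behind it.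

Compound 4 `N#CC1CN1C(=O)Nc1ccc(C(F)(F)F)cc1` keeps the aromatic ring of compound 1 and changes only the substituent: trifluoromethyl in place of ethoxycarbonyl on an aromatic carbon. Going by the values given here, no measured pair in the set shows what such an exchange on the aromatic carbon does; the only measured contrasts concern the replacement of the whole aromatic ring. Keeping the aromatic ring, which compound 1 shows as the favourable feature, the expectation for the step of a 1.3-fold higher number from compound 1 to compound 4 (0.12 log units; within the scatter) is a change within the usual scatter, direction uncertain. Compound 4 is therefore estimated at 4000 nM in this assay, within 1300 nM to 12000 nM.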

Compound 4, half-maximal inhibitory concentration: 8200 nM
Beside the measured number, compound 4's estimate is 2.1-fold (0.31 log units) below it, and the stated range covers the measured number.
By their numbers in this assay, from the lowest: compound 1; then compound 4; then compound 2; then compound 3.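

In this assay, going by these compounds alone, this is the first measured exchange on the aromatic carbon para to a group of 8 heavy atoms: trifluoromethyl in place of ethoxycarbonyl gives a 2.7-fold higher number from compound 1 to compound 4 (0.44 log units; beyond the scatter), a modest step beyond the scatter. The earlier compounds shown here showed only replacement of the whole aromatic ring, whereas this pair shows that, with the ring kept, the number still responds to the group on this carbon, with ethoxycarbonyl giving the lower number of the two. Nothing available here bears on why the number rises with this exchange.

Two groups at one position define no trend. As far as these compounds go, it remains open where a carboxylic acid, an amine or a longer ester chain on this carbon would fall relative to compound 1 and compound 4.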